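This account rests on a few compounds, and the source may have more. Where it says the series, first, only, none or still open, it means among the compounds named here.

Compound 2 `CCCCCCCCCC/C=C/[C@@H](O)[C@H](COC(=O)NCc1ccncc1)NC(=O)C(C)(C)C`: 6800 nM
Compound 1 `CCCCCCCCCCCCC/C=C/[C@@H](O)[C@H](CNC(=O)OCc1ccncc1)NC(=O)C(C)(C)C`: 58000 nM

In an assay on microsomes from brain for inhibition of sphingomyelin phosphodiesterase 2 (Rattus norvegicus) (a lower number here means a stronger inhibitor, a higher number a weaker inhibitor), compound 2 stands at the lowest of the two numbers. Compound 1 gives 58000 nM, a gap well beyond the usual scatter; the two structures differ in more than one place, so the gap is simply what the two values show. Compound 3 `CCCCCCCCCCCCCCC/C=C/[C@@H](O)[C@H](COC(=O)NCc1ccncc1)NC(=O)C(C)(C)C` has not been measured. It differs from compound 2 by pentyl in place of hydrogen on a saturated chain carbon, ten or more bonds along the chain from a double-bonded chain carbon. Within the data shown here, no single-site step of this kind has been measured here. The step from compound 2 to compound 3 is expected to be modest, toward a lower number, a 2.3-fold lower number from compound 2 to compound 3 (0.36 log units; beyond the scatter). Compound 3 is expected to give 3000 nM, within 800 nM to 15000 nM.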

Compound 3, half-maximal inhibitory concentration: 6600 nM
Beside the measured number, compound 3's estimate is 2.2-fold (0.34 log units) below it, and the stated range covers the measured number.
By their numbers in this assay, from the lowest: compounds 3 and 2 (each within the scatter of the next); then compound 1.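

In this assay, pentyl in place of hydrogen on a saturated chain carbon, ten or more bonds along the chain from a double-bonded chain carbon, gives a 1.0-fold lower number from compound 2 to compound 3 (0.01 log units; within the scatter), a step within the scatter. Among these compounds, compound 2 and compound 3 therefore read alike, so at this place the added pentyl leaves the number unmoved, which the earlier compounds could not show. No measured evidence accounts for this result. Still open, as far as these compounds go, is whether an amine or a carboxylic acid on this chain would move the number beyond the scatter.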